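Changing one amide group on compound 3

A few compounds are considered here, and "the series" means these few. Any claim that something is new, unique, unknown or untested is made for them only; others in the source may bear on it.

Measured so far in a functional assay on T47D cells (Homo sapiens) for inhibition, read by CCK-8 assay, with a stated time of 72 h, tested at 1 uM; a lower number here means less inhibition of growth, a higher number more inhibition of growth at the concentration tested
- compound 1 `CN(C)C(=O)c1cc2cnc(Nc3ccc(NC(=O)C4(C(=O)Nc5ccc(F)cc5)CC4)cc3)nc2n1C1CCCC1` gives 74.7%
- compound 2 `Cc1cccc(NC(=O)C2(C(=O)Nc3ccc(Nc4ncc5cc(C(=O)N(C)C)n(C6CCCC6)c5n4)cc3)CC2)c1` gives 45.7%
- compound 3 `COc1ccc(NC(=O)C2(C(=O)Nc3ccc(Nc4ncc5cc(C(=O)N(C)C)n(C6CCCC6)c5n4)cc3)CC2)cc1` gives 76.4%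

Compound 3 shares the top of this small set with compound 1, with a number 1.7 percentage points higher from compound 1 to compound 3 (within the scatter). Compound 2 is clearly separate, with a number 30.7 percentage points higher from compound 2 to compound 3 (beyond the scatter).

The next compound is compound 4 `CN(C)C(=O)c1cc2cnc(Nc3ccc(NC(=O)C4(C(=O)Nc5ccc(Cl)c(C(F)(F)F)c5)CC4)cc3)nc2n1C1CCCC1`, which differs from compound 3 in one place: 4-chloro-3-(trifluoromethyl)phenyl in place of 4-methoxyphenyl on an amide-type nitrogen. In words, 4-chloro-3-(trifluoromethyl)phenyl stands in place of 4-methoxyphenyl on an amide-type nitrogen.

Within the data shown here, two measured steps bear on this. Changing the group named with a 4 made no clear difference, as compound 3 showed with a number 1.7 percentage points higher from compound 1 to compound 3 (within the scatter). Moving to a group named with a 3 did matter, as compound 2 showed with a number 29 percentage points lower from compound 1 to compound 2 (beyond the scatter). Among the measured compounds shown here, the new group carries both kinds of substituent, and no measured compound contains chloro or trifluoromethyl, so the guess is loose. A modest fall is expected, which would be a number 16.4 percentage points lower from compound 3 to compound 4 (beyond the scatter). For compound 4 the estimated value is 60%, within an expected range of 35% to 85%.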

Compound 4, percent growth inhibition at one concentration: 6.9%
Compound 4: middle estimate off by 53.1 percentage points, on the high side; measured number outside the range, below it.
By their numbers in this assay, from the lowest: compound 4; then compound 2; then compounds 1 and 3 (each within the scatter of the next).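

In this assay, the 4-chloro-3-(trifluoromethyl)phenyl group on this amide nitrogen gives a number 69.5 percentage points lower from compound 3 to compound 4 (beyond the scatter), and the loss is also large against the other two rings, with a number 67.8 percentage points lower from compound 1 to compound 4 (beyond the scatter) and a number 38.8 percentage points lower from compound 2 to compound 4 (beyond the scatter). The earlier compounds shown here showed that changing this ring could leave growth inhibition unchanged or lower it substantially, whereas compound 4 shows that one such change can leave little inhibition at the concentration tested. Nothing measured here explains the fall.

The compounds shown leave open whether the loss follows the chloro, the trifluoromethyl or the two together, which a phenyl ring carrying only one of them would help separate. Also open, as far as these compounds go, is how a phenyl ring carrying an amine or a carboxylic acid would behave at this position.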